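The compounds below may be only part of what the source reports. "The series", "measured", "known", "first", "only" and "open" are said of these compounds alone.

Measured compounds in an assay on CHO cells for displacement of a labelled ligand from Substance-P receptor (Homo sapiens); on this read-out lower numbers stand for stronger inhibition and higher numbers for weaker inhibition:
- compound 1, `C[C@@H](O[C@H]1CN2C(=O)C=C(c3ccccc3)CC2[C@@H]1c1ccc(F)cc1)c1cc(C(F)(F)F)cc(C(F)(F)F)c1`: 0.93 nM
- compound 2, `C[C@@H](O[C@H]1CN2C(=O)C=C(c3ccc(C#N)cc3)CC2[C@@H]1c1ccc(F)cc1)c1cc(C(F)(F)F)cc(C(F)(F)F)c1`: 1.8 nM
- compound 3, `C[C@@H](O[C@H]1CN2C(=O)C=C(c3ccc(F)cc3)CC2[C@@H]1c1ccc(F)cc1)c1cc(C(F)(F)F)cc(C(F)(F)F)c1`: 2 nM

Compound 3 gives the highest of the three numbers in this assay; the two steps that end at it are a 1.1-fold higher number from compound 2 to compound 3 (0.05 log units; within the scatter) and a 2.2-fold higher number from compound 1 to compound 3 (0.33 log units; beyond the scatter). All three numbers therefore sit close together on the shared core, with only the substituent on the six-membered aromatic ring of carbon only being varied.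

Compound 4, `C[C@@H](O[C@H]1CN2C(=O)C=C(c3ccc(NS(C)(=O)=O)cc3)CC2[C@@H]1c1ccc(F)cc1)c1cc(C(F)(F)F)cc(C(F)(F)F)c1`, is not yet measured. Its difference from compound 3 is methanesulfonamido in place of fluoro on an aromatic carbon. The two measured steps that touch the same ring carbon are a 2.2-fold higher number from compound 1 to compound 3 (0.33 log units; beyond the scatter) and a 1.1-fold higher number from compound 2 to compound 3 (0.05 log units; within the scatter); a third, a 1.9-fold higher number from compound 1 to compound 2 (0.29 log units; within the scatter), shows that hydrogen and nitrile at that carbon also lie within the scatter of each other. For the measured compounds named here, none of these steps introduces a group with a hydrogen-bond donor, so there is no direct precedent for methanesulfonamido, and the expectation rests on the narrow spread seen so far. A small step is expected, if anything towards a higher number, in this assay.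

Compound 4 is estimated at 3 nM, with a range from 1 nM to 10 nM, which means an expected step of a 1.5-fold higher number from compound 3 to compound 4 (0.18 log units; within the scatter).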

Compound 4, half-maximal inhibitory concentration: 1 nM
Beside the measured number, compound 4's estimate is 3.0-fold (0.48 log units) above it; low and high end bracket the measured number.
By their numbers in this assay, from the lowest: compounds 1, 4, 2 and 3 (each within the scatter of the next, the first and the last beyond it).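

In this assay, the aromatic carbon para to a large group accepts methanesulfonamido, with its 5 heavy atoms and 1 hydrogen-bond donor, and every step to it stays within the scatter (a 2.0-fold lower number from compound 3 to compound 4 (0.30 log units; within the scatter); a 1.8-fold lower number from compound 2 to compound 4 (0.26 log units; within the scatter); a 1.1-fold higher number from compound 1 to compound 4 (0.03 log units; within the scatter)). The earlier compounds shown here held only hydrogen, fluoro and nitrile at this carbon, none of them with a hydrogen-bond donor, so the narrow spread at this position now also covers a group of a different kind, as far as these four compounds go. Nothing given here accounts for methanesulfonamido reading level with hydrogen, nitrile and fluoro at this carbon.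

Open, as far as these compounds go, is whether an amine, a carboxylic acid or a longer chain such as a butanesulfonamido group at this carbon would stay within the same narrow spread, and whether the nitrogen-methylated methanesulfonamido group, which has no amide hydrogen, would read the same. Also open, from the compounds shown here alone, is whether methanesulfonamido on another carbon of this ring would give a similar number in this assay on the shared core.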